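Undecyl to 2-methylprop-1-en-1-yl on compound 3

The compounds below may be only part of what the source reports. "The series", "measured", "known", "first", "only" and "open" are said of these compounds alone.

Of the compounds shown here, three have been measured in a functional assay on MCF7 cells (Homo sapiens) for cytotoxicity, read by colony formation; a higher number here means a weaker inhibitor, a lower number a stronger inhibitor. Compound 1 `COC(=O)C1=CO[C@@H](O[C@@H]2O[C@H](COC(c3ccccc3)(c3ccccc3)c3ccccc3)[C@@H](O)[C@H](O)[C@H]2O)[C@@H]2[C@@H](C)[C@@H](O)C[C@H]12` gives 2.8 ug/mL and compound 2 `CCC(=O)OC[C@H]1O[C@@H](O[C@@H]2OC=C(C(=O)OC)[C@H]3C[C@H](OC(C)=O)[C@H](C)[C@@H]23)[C@H](OC(C)=O)[C@@H](OC(C)=O)[C@@H]1OC(C)=O` gives 4.26 ug/mL. Compound 3 `CCCCCCCCCCCC(=O)OC[C@H]1O[C@@H](O[C@@H]2OC=C(C(=O)OC)[C@H]3C[C@H](OC(C)=O)[C@H](C)[C@@H]23)[C@H](OC(C)=O)[C@@H](OC(C)=O)[C@@H]1OC(C)=O` gives 0.75 ug/mL, the lowest number of the three.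

Compound 4 `COC(=O)C1=CO[C@@H](O[C@@H]2O[C@H](COC(=O)C=C(C)C)[C@@H](OC(C)=O)[C@H](OC(C)=O)[C@H]2OC(C)=O)[C@@H]2[C@@H](C)[C@@H](OC(C)=O)C[C@H]12` has 2-methylprop-1-en-1-yl in place of undecyl on a carbonyl carbon. Within the data shown here, one measured step bears on this change: a 5.7-fold lower number from compound 2 to compound 3 (0.75 log units; beyond the scatter), which adds nonyl to the chain on that carbonyl carbon. Among the measured compounds shown here, no measured compound carries the entering group, and a single step cannot show how the number follows chain length. Even so, the entering group is much shorter than undecyl, so with a 5.7-fold lower number from compound 2 to compound 3 (0.75 log units; beyond the scatter) as the only guide, much of that step is expected to reverse. The expected change is a 3.7-fold higher number from compound 3 to compound 4 (0.57 log units; beyond the scatter), towards a higher number and beyond the scatter. For compound 4 the estimated value is 2.8 ug/mL, with an expected range of 1.2 ug/mL to 6.5 ug/mL.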

Compound 4, half-maximal inhibitory concentration: 4.65 ug/mL
The estimate for compound 4 lay 1.7-fold (0.22 log units) below the measured number; the measured number falls inside the stated range.
By their numbers in this assay, from the lowest: compound 3; then compounds 1, 2 and 4 (each within the scatter of the next).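

In this assay, replacing undecyl with 2-methylprop-1-en-1-yl on the carbonyl carbon gives a 6.2-fold higher number from compound 3 to compound 4 (0.79 log units; beyond the scatter), so the low number of compound 3 is not kept with this four-carbon group. Ethyl and 2-methylprop-1-en-1-yl on that carbon are not distinguished, with a 1.1-fold higher number from compound 2 to compound 4 (0.04 log units; within the scatter), so the double bond in the entering group brings no change beyond the scatter in this pair. Among compound 2, compound 3 and compound 4, only the undecyl ester stands apart, and no evidence at hand accounts for this.

Still open, going by these compounds, is where between ethyl and undecyl the number begins to fall, for example with a hexyl chain, and whether a longer chain such as pentadecyl goes lower still. Also open, on these data alone, is whether an undecyl chain carrying an amine or a carboxylic acid would keep the low number of compound 3.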